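This account rests on a few compounds, and the source may have more. Where it says the series, first, only, none or still open, it means among the compounds named here.

Among the compounds with values here, in a functional assay on MDA-MB-231 cells (Homo sapiens) for antiproliferative activity, read by sulforhodamine B assay, with a stated time of 72 h (on this read-out lower numbers stand for stronger inhibition and higher numbers for weaker inhibition), compound 1 `Cc1ccc(S(=O)(=O)Nc2cc(SCC(=O)N[C@@H](CC(C)C)B(O)O)c(O)c3ccccc23)cc1` gives 14000 nM and compound 2 `CC(C)C[C@H](NC(=O)CSc1cc(NS(=O)(=O)c2ccccc2)c2ccccc2c1O)B(O)O` gives 10600 nM with no separation beyond the scatter, so compound 1 stands level with its only measured neighbour. That step, a 1.3-fold lower number from compound 1 to compound 2 (0.12 log units; within the scatter), places hydrogen in place of methyl on an aromatic carbon and offers no direct guide to compound 3 `Cc1ccc(S(=O)(=O)Nc2cc(SC(C)C(=O)N[C@@H](CC(C)C)B(O)O)c(O)c3ccccc23)cc1` which carries methyl in place of hydrogen on a saturated chain carbon bound to a carbonyl carbon and a sulfur in the core of compound 1. Within the data shown here, no measured step gives a direction, so the expected change of a 1.2-fold lower number from compound 1 to compound 3 (0.07 log units; within the scatter) is none beyond the scatter. For compound 3 the estimated value in this assay is 12000 nM with an expected range from 5000 nM to 30000 nM as its bounds.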

Compound 3, half-maximal inhibitory concentration: 8130 nM
For compound 3 the middle estimate is 1.5-fold (0.17 log units) above the measured one, within the range that was stated.
By their numbers in this assay, from the lowest: compounds 3, 2 and 1 (each within the scatter of the next).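

The first change shown on the saturated chain carbon bound to a carbonyl carbon and a sulfur, methyl in place of hydrogen, gives a 1.7-fold lower number from compound 1 to compound 3 (0.24 log units; within the scatter) in this assay and so leaves compound 3 level with compound 1. At this position, one added carbon does not separate the two compounds on this read-out. Nothing available explains this result.

On these data alone, whether an ethyl group, an amine or a carboxylic acid on this carbon would move the number beyond the scatter stays open. So does whether any change here can do so in the core of compound 2.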